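A few compounds are considered here, and "the series" means these few. Any claim that something is new, unique, unknown or untested is made for them only; others in the source may bear on it.

Measured so far in a functional assay on cells (Neutrophil, Homo sapiens) for inhibition, with a stated time of 10 min; a higher number here means a weaker inhibitor, a lower number a stronger inhibitor

- Compound 1 `CCOC(=O)c1cnn2c1N(C(=O)Nc1cccc(F)c1)C(c1ccccc1)C2` gives 111 nM
- Compound 2 `O=C(NC1CC1)c1cnn2c1N(C(=O)Nc1cccc(F)c1)C(c1ccccc1)C2` gives > 1000 nM as a limit of the assay, not a number

Compound 2 has no exact value and sits at the weak end of what was measured (the limit of > 1000 nM in this assay, at which 1 of the 2 values shown sits). Compound 3 `O=C(c1cnn2c1N(C(=O)Nc1cccc(F)c1)C(c1ccccc1)C2)N1CCCCC1` differs from compound 2 on a carbonyl carbon, with piperidin-1-yl in place of cyclopropylamino (piperidin-1-yl in place of cyclopropylamino on a carbonyl carbon). Among the measured compounds shown here, the one measured step at that carbonyl carbon (an at least 9.0-fold higher number from compound 1 to compound 2 (0.95 log units; beyond the scatter)) put cyclopropylamino in place of ethoxy and lies beyond the scatter, towards a weaker inhibitor. That step replaced ethoxy, whereas the new change swaps one nitrogen-linked ring for another, so it gives no clear direction. Weak inhibition is expected to persist, with no change beyond the scatter expected (estimated step: a step that the limit leaves unreadable from compound 2 to compound 3). For compound 3 the estimated value is 1500 nM (expected range 400 nM to 6000 nM).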

Compound 3, half-maximal inhibitory concentration: 1.2 nM
Compound 3: middle estimate off by 1300-fold (3.10 log units), on the high side; the whole stated range lies above it.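

In this assay, the group on this carbonyl carbon proves decisive, and swapping one nitrogen-linked ring for another gives an at least 830-fold lower number from compound 2 to compound 3 (2.92 log units; beyond the scatter). Compound 2 stands only as a limit of the assay: the limit of > 1000 nM in this assay, at which 1 of the 3 values shown sits. Set against the ethoxy group, piperidin-1-yl gives a 93-fold lower number from compound 1 to compound 3 (1.97 log units; beyond the scatter), so replacing ethoxy with a nitrogen-linked ring can go either way here: compound 2 moves towards a weaker inhibitor and compound 3 towards a stronger one.

Cyclopropylamino and piperidin-1-yl differ both in ring size and in hydrogen-bond donors, with one on cyclopropylamino and none on piperidin-1-yl, and the compounds shown do not separate these two differences. From the compounds shown here alone, it remains open whether a pyrrolidin-1-yl, morpholin-4-yl or open-chain dimethylamino group on this carbonyl carbon would match compound 3.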